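This account rests on a few compounds, and the source may have more. Where it says the series, first, only, none or still open, it means among the compounds named here.

Compound 1 `COc1cnc(-c2ccccn2)nc1N(C)C1CCCC1` is the starting point, and in a functional assay on RAW264.7 cells (Mus musculus), with a stated time of 3 days (a lower number here means a stronger inhibitor, a higher number a weaker inhibitor), compound 1 gives 180 nM. Two relatives offer context: compound 2 `COc1cnc(-c2ccccn2)nc1NCc1ccccc1C` gives 220 nM, and compound 3 `COc1cnc(-c2ccccn2)nc1NCc1ccccc1F` gives 130 nM. These three numbers lie within the scatter of one another, so compound 1 stands level with both, and no ranking can be drawn among them.

Compound 4 `COc1cnc(-c2ccccn2)nc1NC1CCCC1` has not yet been measured. It differs from compound 1 by one small edit, hydrogen in place of methyl on a nitrogen on an aromatic ring, so that cyclopentyl(methyl)amino becomes cyclopentylamino.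

Among the compounds with values here, the only measured step is a 1.7-fold lower number from compound 2 to compound 3 (0.23 log units; within the scatter), which puts fluoro in place of methyl on an aromatic carbon. It is a different change and lies within the scatter, so it offers only weak guidance here. Within the data shown here, no measured pair isolates the loss of this methyl. Compound 2 and compound 3 do carry a hydrogen on that nitrogen, but they also differ from compound 1 in the group attached there. A small step in this assay is therefore expected, with only a slight lean towards a lower number. The estimated step is a 1.4-fold lower number from compound 1 to compound 4 (0.14 log units; within the scatter). Compound 4 is expected at about 130 nM, within an estimated range of 45 nM to 380 nM.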

Compound 4, half-maximal inhibitory concentration: 570 nM
For compound 4 the middle estimate is 4.4-fold (0.64 log units) below the measured one; the measured number lies above the stated range.
By their numbers in this assay, from the lowest: compounds 3, 1 and 2 (each within the scatter of the next); then compound 4.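

Hydrogen in place of methyl on this nitrogen gives a 3.2-fold higher number from compound 1 to compound 4 (0.50 log units; beyond the scatter) in this assay, so this small edit has a modest but readable effect. Within the data shown here, it is the only step in this set that lies beyond the scatter, and it shows that the methyl on this nitrogen matters when the other group there is cyclopentyl. The earlier compounds could not show this, as compound 2 and compound 3 carry a hydrogen on that nitrogen but differ from compound 1 in the attached group as well, and nothing here accounts for the size or direction of the new step.

From the compounds shown here alone, it remains open whether an ethyl group or a longer chain in place of the methyl would hold the number near that of compound 1, or whether the number depends on having any carbon group on this nitrogen at all. Among these compounds, also open is whether the same edit would have a similar effect with the groups carried by compound 2 and compound 3, since here it is seen only with cyclopentyl.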